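The compounds below may be only part of what the source reports. "The series", "measured", "known", "first", "only" and "open" are said of these compounds alone.

In a functional assay on MCF7 cells (Homo sapiens) for antiproliferative activity (on this read-out higher numbers stand for weaker inhibition and lower numbers for stronger inhibition), compound 1 `CC(=O)Oc1ccc(C(=O)Nc2cc3ccc(OCCC4CCCCN4)c(C)c3oc2=O)cc1CC=C(C)C` gives 710 nM, compound 2 `CC(C)=CCc1cc(C(=O)Nc2cc3ccc(OCC4CCCNC4)c(C)c3oc2=O)ccc1O` gives 790 nM and compound 3 `CC(C)=CCc1cc(C(=O)Nc2cc3ccc(OCCCN4CCCC4)c(C)c3oc2=O)ccc1O` gives 990 nM. Compound 2 lies within the scatter of both other compounds, so these numbers set no clear ranking. Compound 4 `CCCNCCCOc1ccc2cc(NC(=O)c3ccc(O)c(CC=C(C)C)c3)c(=O)oc2c1C` has not yet been measured. It differs from compound 2 by one change: 2-(propylamino)ethyl in place of piperidin-3-yl on a saturated chain carbon bound to an oxygen on an aromatic ring. Among the compounds with values here, the only measured step at this place is a 1.3-fold higher number from compound 2 to compound 3 (0.10 log units; within the scatter), and it also replaces piperidin-3-yl, with a group that differs from the one in compound 4. On that single precedent, no change beyond the scatter is expected in this assay, and the estimated step is a 1.1-fold higher number from compound 2 to compound 4 (0.03 log units; within the scatter). For compound 4 the expected value is 850 nM, with an estimated range of 380 nM to 1900 nM.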

Compound 4, half-maximal inhibitory concentration: 980 nM
For compound 4 the middle estimate is 1.2-fold (0.06 log units) below the measured one; low and high end bracket the measured number.
By their numbers in this assay, from the lowest: compounds 1, 2, 4 and 3 (each within the scatter of the next).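

In this assay, putting 2-(propylamino)ethyl in place of piperidin-3-yl gives a 1.2-fold higher number from compound 2 to compound 4 (0.09 log units; within the scatter), so among these compounds an open chain serves at this place as well as a ring. Propylamino in place of pyrrolidin-1-yl gives a 1.0-fold lower number from compound 3 to compound 4 (0.00 log units; within the scatter), which likewise separates open chain from ring by no measurable margin. Nothing available here speaks to the reason for this.

As far as these compounds go, whether the nitrogen matters at all remains open. A chain ending in a hydroxyl or a carboxylic acid, or a longer chain, lies outside the compounds shown.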